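From amide to benzylamino on the shared core

The source may report more compounds than this note shows. Statements on the series, on what has been measured and on what is new or still open speak of the compounds shown alone.

Values in a functional assay on HUVEC cells (Homo sapiens) for inhibition, with stated times of 2 h and 72 h (on this read-out lower numbers stand for stronger inhibition and higher numbers for weaker inhibition), each a limit of the assay and not a number:
- compound 1 `COc1cc2nccc(Oc3ccc4c(NC(=O)Nc5ccc(C(F)(F)F)cc5Cl)nn(C)c4c3)c2cc1OC`: > 1000 nM
- compound 2 `COc1cccc(Nc2nn(C)c3cc(Oc4ccnc5cc(OC)c(OC)cc45)ccc23)c1`: > 1000 nM
- compound 3 `COc1ccc(C(=O)Nc2nn(C)c3cc(Oc4ccnc5cc(OC)c(OC)cc45)ccc23)cc1`: > 1000 nM

Compound 3 has no number here, only the limit of > 1000 nM. Among the compounds with values here, the whole series so far shares that position: the limit of > 1000 nM in this assay, at which 3 of the 3 values shown sit.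

Compound 4 `COc1cc2nccc(Oc3ccc4c(NCc5ccccc5)nn(C)c4c3)c2cc1OC` carries benzyl in place of (4-methoxyphenyl)carbonyl on a nitrogen on an aromatic ring. The same difference, cut one bond further out, reads ((4-methoxyphenyl)carbonyl)amino to benzylamino.

Within the data shown here, the closest precedent is a change on that same nitrogen: a step that the two limits leave unreadable from compound 2 to compound 3. A second change on the carbonyl carbon gives no more: a step that the two limits leave unreadable from compound 1 to compound 3. Neither offers a size to carry over, so no clear step in either direction is expected in this assay, and another limit is the likeliest report. The estimated step is a step that the limit leaves unreadable from compound 3 to compound 4. For compound 4 the estimate is 2000 nM, with an expected range of 600 nM to 6000 nM.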

Compound 4, half-maximal inhibitory concentration: > 1000 nM
Compound 4 ended at the assay's limit; the forecaster's own chance of this, stated with the estimate: 85%; the middle value does not contradict the limit.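

Compound 4 gives > 1000 nM in this assay, a limit of the assay and not a number. The steps to it from compound 2 and from compound 3 cannot be read, as both ends are limits. The compounds shown leave open which change on the shared core alters inhibition, and by how much: the limit of > 1000 nM in this assay, at which 4 of the 4 values shown sit.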